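Swapping Methoxy for Chloro in a Glutamate Receptor Modulator

The source may hold more compounds than are shown below. What is called first, only, known or untested is meant among the compounds shown, and "the series" means these compounds.

Of the compounds shown here, three have been measured in an assay for positive allosteric modulation of metabotropic glutamate receptor 2 (Rattus norvegicus); on this read-out lower numbers stand for an effect already at smaller amounts and higher numbers for an effect only at larger amounts of compound. Compound 1 `Cc1c(OC[C@H](C)Oc2ccc(F)c(C(=O)O)c2)ccc(C(=O)CC(C)(C)C)c1O` gives 142 nM, compound 2 `COc1ccc(C(=O)O)cc1OC[C@@H](C)Oc1ccc(C(=O)CC(C)(C)C)c(O)c1C` gives 78 nM, and compound 3 `COc1cc(C(=O)O)ccc1OC[C@H](C)COc1ccc(C(=O)CC(C)(C)C)c(O)c1C` gives 28 nM, the lowest of the three numbers, with both other values lying beyond the usual scatter from it. Compound 4 `Cc1c(OC[C@@H](C)COc2ccc(C(=O)O)cc2Cl)ccc(C(=O)CC(C)(C)C)c1O` has not yet been measured. It differs from compound 3 in a single place: chloro in place of methoxy on an aromatic carbon. Going by the values given here, no measured pair shows this same change, so nothing here tells directly how large its effect is. In this assay the expected step is a 1.6-fold higher number from compound 3 to compound 4 (0.21 log units; within the scatter), a modest move toward a higher number that may well stay within the scatter. Compound 4 is therefore estimated at 45 nM, within a range from 15 nM to 140 nM.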

Compound 4, half-maximal effective concentration: 477 nM
Estimate against measurement, compound 4: 11-fold (1.03 log units) below; the whole stated range lies below it.
By their numbers in this assay, from the lowest: compound 3; then compounds 2 and 1 (each within the scatter of the next); then compound 4.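

Chloro in place of methoxy on this aromatic carbon, ortho to a large group and meta to a carboxy group, gives a 17-fold higher number from compound 3 to compound 4 (1.23 log units; beyond the scatter) in this assay. This position is therefore far from indifferent to what sits on it, and of these two groups methoxy goes with the much lower number. No measured property of these compounds bears on the size of this step.

The compounds shown leave open how other groups on this carbon, such as ethoxy or a nitrile, would compare. They also leave open whether the same swap would have a similar effect on a different core.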